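Carbamate cap trimmed: phenyl to isopropyl in compound 4

A few compounds are considered here, and "the series" means these few. Any claim that something is new, unique, unknown or untested is made for them only; others in the source may bear on it.

The series shares the core of compound 1 `CN(C)c1ccc(C(=O)N[C@@H](CCCCCC(=O)NO)C(=O)Nc2cccc3cccnc23)cc1` and varies only the cap on the amine. In a functional assay on PC-3 cells (Homo sapiens) for antiproliferative activity (on this read-out lower numbers stand for stronger inhibition and higher numbers for weaker inhibition), compound 1 gives 220 nM. Compound 2 `O=C(/C=C/c1ccccc1)N[C@@H](CCCCCC(=O)NO)C(=O)Nc1cccc2cccnc12` gives 109 nM in this assay, and compound 3 `O=C(CCCCC[C@H](NC(=O)OCc1ccccc1)C(=O)Nc1cccc2cccnc12)NO` gives 528 nM. Compound 3 thus stands at the highest number of the three: the steps of a 2.4-fold higher number from compound 1 to compound 3 (0.38 log units; beyond the scatter) and a 4.8-fold higher number from compound 2 to compound 3 (0.69 log units; beyond the scatter) both run toward weaker inhibition, whereas a 2.0-fold lower number from compound 1 to compound 2 (0.30 log units; within the scatter) stays within the scatter.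

Compound 4 `CC(C)COC(=O)N[C@@H](CCCCCC(=O)NO)C(=O)Nc1cccc2cccnc12` keeps the carbamate of compound 3 and alters its outer part: isopropyl in place of phenyl on a saturated chain carbon bound to an oxygen next to a carbonyl group. Among the measured compounds shown here, none of the measured steps touches this position. The two steps ending at compound 3 concern exchange of the 4-(dimethylamino)phenyl or 2-phenylethenyl cap for benzyloxy, so they describe whole-cap swaps rather than a change inside the benzyloxy group. Nothing in the measured set points to a gain at this position. For compound 4 the expected step is a 1.4-fold higher number from compound 3 to compound 4 (0.15 log units; within the scatter), modest at most and toward a higher number, with no step beyond the scatter ruled out. Compound 4 is therefore estimated at 750 nM, with a range of 300 nM to 1900 nM.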

Compound 4, half-maximal inhibitory concentration: 651 nM
For compound 4 the middle estimate is 1.2-fold (0.06 log units) above the measured one; the range from low to high includes it.
By their numbers in this assay, from the lowest: compounds 2 and 1 (each within the scatter of the next); then compounds 3 and 4 (each within the scatter of the next).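

In this assay the step of a 1.2-fold higher number from compound 3 to compound 4 (0.09 log units; within the scatter) stays within the scatter, so on a saturated chain carbon bound to an oxygen next to a carbonyl group, the aromatic ring of the phenyl can give way to isopropyl without a readable difference. The carbamate cap now has two outer groups, benzyloxy and isobutoxy, and the isobutoxy cap repeats the direction seen for benzyloxy: the steps of a 3.0-fold higher number from compound 1 to compound 4 (0.47 log units; beyond the scatter) and a 6.0-fold higher number from compound 2 to compound 4 (0.78 log units; beyond the scatter) both lie beyond the scatter and run toward weaker inhibition, so the standing of the carbamates in this small set does not rest on the phenyl alone. No independent data bear on why the outer group of the carbamate makes so little difference here.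

Still open is whether a carboxylic acid or an amine at the outer end of the isobutoxy group would move the number beyond the scatter, since both outer groups shown are plain hydrocarbon. From the compounds shown here alone, a longer chain in place of isobutyl is equally untested in these compounds, so how far this tolerance extends remains unknown.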